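Swapping an amide for a sulfonamide on a chalcone-type scaffold

A few compounds are considered here, and "the series" means these few. Any claim that something is new, unique, unknown or untested is made for them only; others in the source may bear on it.

Measured compounds:
- Compound 1, `O=C(Nc1cccc(/C=C/C(=O)c2nc3ccccc3[nH]2)c1)c1cccc(Br)c1`: 5210 nM
- Compound 2, `Cc1ccc(C(=O)Nc2cccc(/C=C/C(=O)c3nc4ccccc4[nH]3)c2)cc1`: 9690 nM
- Compound 3, `Cc1cc(C)cc(C(=O)Nc2cccc(/C=C/C(=O)c3nc4ccccc4[nH]3)c2)c1`: 24600 nM

All three share the same core and differ only in the aryl group attached to the carbonyl carbon of the amide. In a functional assay on MCF7 cells (Homo sapiens) for antiproliferative activity, read by MTT assay, with a stated time of 48 h (on this read-out lower numbers stand for stronger inhibition and higher numbers for weaker inhibition), compound 3 gives the highest number of the three, and both of its steps to the others lie beyond the scatter: a 4.7-fold higher number from compound 1 to compound 3 (0.67 log units; beyond the scatter) and a 2.5-fold higher number from compound 2 to compound 3 (0.40 log units; beyond the scatter). Compound 1 and compound 2 differ from each other only within the scatter, a 1.9-fold higher number from compound 1 to compound 2 (0.27 log units; within the scatter).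

Compound 4, `O=C(/C=C/c1cccc(NS(=O)(=O)c2cccc(Cl)c2)c1)c1nc2ccccc2[nH]1`, is not yet measured. It differs from compound 3 by (3-chlorophenyl)sulfonyl in place of (3,5-dimethylphenyl)carbonyl on a nitrogen on an aromatic ring. Within the data shown here, two measured steps bear on this change. The step of a 4.7-fold higher number from compound 1 to compound 3 (0.67 log units; beyond the scatter) shows that a single halogen on the aryl ring goes with a lower number than the 3,5-dimethylphenyl group, and the step of a 2.5-fold higher number from compound 2 to compound 3 (0.40 log units; beyond the scatter) points the same way for a single methyl. Among the measured compounds shown here, no measured pair covers the exchange of a carbonyl for a sulfonyl, so that part of the change is unanchored. The expectation is therefore a modest move toward a lower number in this assay, of about a 3.8-fold lower number from compound 3 to compound 4 (0.58 log units; beyond the scatter), with wide uncertainty. Compound 4 is estimated at 6500 nM, with a range from 1500 nM to 28000 nM.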

Compound 4, half-maximal inhibitory concentration: 4160 nM
Estimate against measurement, compound 4: 1.6-fold (0.19 log units) above, within the range that was stated.
By their numbers in this assay, from the lowest: compounds 4, 1 and 2 (each within the scatter of the next, the first and the last beyond it); then compound 3.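

Among these compounds, compound 4 is the first here with a sulfonyl in place of the carbonyl on the nitrogen, and in this assay the swap costs nothing measurable when a halogen-bearing aryl ring is kept: a 1.3-fold lower number from compound 1 to compound 4 (0.10 log units; within the scatter), so the two cannot be told apart. The methyl-bearing amides give different steps, a 2.3-fold lower number from compound 2 to compound 4 (0.37 log units; beyond the scatter) and a 5.9-fold lower number from compound 3 to compound 4 (0.77 log units; beyond the scatter), but each of these changes the aryl group and the carbonyl together, so the share of each change cannot be separated, and even the step against compound 1 swaps bromine for chlorine as well. Nothing available explains why these numbers fall as they do, and no independent measurement bears on this result.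

Isolating the sulfonyl would take a pair with an identical aryl group, such as a (3-chlorophenyl)carbonyl amide set against compound 4, and the compounds shown hold no such pair. Also open, going by these compounds, is how an aryl ring carrying a methoxy group, an amine or a carboxylic acid would behave on the sulfonyl, or how a longer chain would behave in place of that ring.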